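Oxolanyl for Cyclopropyl on a Shared Diamine Core

A few compounds are considered here, and "the series" means these few. Any claim that something is new, unique, unknown or untested is made for them only; others in the source may bear on it.

Compound 1 `COc1ccc(-c2nc3cc(C)c(C)cc3n2-c2ccc3c(N)nc(N)nc3c2)cc1`: 2300 nM
Compound 2 `Cc1cc2nc(C3CC3)n(-c3ccc4c(N)nc(N)nc4c3)c2cc1C`: 1160 nM

Both compounds were measured in an assay on isolated protein for inhibition of Dihydrofolate reductase (Homo sapiens), read by spectrophotometry, using NADPH, with a stated time of 10 min; on this read-out higher numbers stand for weaker inhibition and lower numbers for stronger inhibition. Compound 2 gives the lowest of the two numbers, with compound 1 nearest; the gap is a 2.0-fold lower number from compound 1 to compound 2 (0.30 log units; within the scatter), so the two are not separated with confidence.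

Compound 3 `Cc1cc2nc(C3CCOC3)n(-c3ccc4c(N)nc(N)nc4c3)c2cc1C` is not yet measured. It differs from compound 2 in one place: oxolan-3-yl in place of cyclopropyl on an aromatic carbon. Among the measured compounds shown here, the only measured step on this position, a 2.0-fold lower number from compound 1 to compound 2 (0.30 log units; within the scatter), swapped a 4-methoxyphenyl for a cyclopropyl and stayed within the scatter. For the measured compounds named here, no measured step exchanges a carbocyclic ring for a five-membered ring with one hetero atom, so the data give no direct guide for the oxolan-3-yl. Given that the one change at this position left the read-out in this assay essentially unmoved, compound 3 is expected to stay close to compound 2, with a step of about a 1.2-fold higher number from compound 2 to compound 3 (0.08 log units; within the scatter) and no clear direction beyond the scatter. The estimate for compound 3 in this assay is 1400 nM, within a range of 450 nM to 4500 nM.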

Compound 3, inhibition constant: > 5000 nM
Compound 3: a limit, no number; the forecaster's own chance of this, stated with the estimate: 0%; middle value at least 3.5-fold (0.55 log units) away from the limit.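

Compound 3 sits at a limit of the assay, not at a number: the limit of > 5000 nM in this assay, at which 1 of the 3 values shown sits. The position is not indifferent to what it carries in this assay: the earlier exchange of 4-methoxyphenyl for cyclopropyl stayed within the scatter, whereas oxolan-3-yl in place of cyclopropyl gives an at least 4.3-fold higher number from compound 2 to compound 3 (0.63 log units; beyond the scatter). Among the compounds shown here, the change away from 4-methoxyphenyl reads the same way, with an at least 2.1-fold higher number from compound 1 to compound 3 (0.33 log units; beyond the scatter), so compound 1 and compound 2, which cannot be told apart from each other, both carry lower numbers than compound 3, and the one group here with a ring oxygen is the one that stands apart.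

As far as these compounds go, with only a limit for compound 3, the full size of both steps stays unknown, and the three compounds cannot show whether the ring oxygen or the five-membered ring goes with the loss. Cyclopentyl, the five-membered ring of carbon only, would separate those two readings, and pyrrolidin-3-yl, with a ring amine in place of the oxygen, would show whether the kind of hetero atom matters at this position.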